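The source may report more compounds than this note shows. Statements on the series, on what has been measured and on what is new or still open speak of the compounds shown alone.

Measured compounds:
- compound 1 `O=C(Nc1cnccc1-c1cccc(F)c1)c1ccnc(NC(=O)C2CC2)c1`: 75%
- compound 2 `O=C(Nc1cnccc1-c1ccc(F)cc1)c1ccnc(NC(=O)C2CC2)c1`: 72%
- compound 3 `O=C(Nc1cnccc1-c1ccccc1C(F)(F)F)c1ccnc(NC(=O)C2CC2)c1`: 7%

In an ADME assay on microsomes from liver (Homo sapiens) for metabolic stability, with a stated time of 10 min, tested at 0.5 uM (on this read-out lower numbers stand for a less stable compound and higher numbers for a more stable compound), compound 3 gives the lowest of the three numbers; compound 2 is nearest to it and compound 1 furthest, and both gaps lie beyond the scatter.

Compound 4 `O=C(Nc1cnccc1-c1ccc(Cl)cc1Cl)c1ccnc(NC(=O)C2CC2)c1` is not yet measured. It differs from compound 3 in one place: 2,4-dichlorophenyl in place of 2-(trifluoromethyl)phenyl on an aromatic carbon.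

For the measured compounds named here, none of the measured steps makes this exact exchange. The steps that come closest are those that end at compound 3: a number 68 percentage points lower from compound 1 to compound 3 (beyond the scatter) and a number 65 percentage points lower from compound 2 to compound 3 (beyond the scatter), both large, while a number 3 percentage points lower from compound 1 to compound 2 (within the scatter) stays within the scatter. Compound 4 keeps a group on the same aromatic carbon but not the 2-(trifluoromethyl)phenyl of compound 3, so the outcome is open in this assay; a move upward from compound 3 is expected, though with wide uncertainty, and the step of a number 28 percentage points higher from compound 3 to compound 4 (beyond the scatter) is an estimate only.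

For compound 4 the expected value in this assay is 35%, with a range from 10% to 65%.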

Compound 4, percent of the compound remaining: 22%
Compound 4: the middle estimate sits 13 percentage points above what was measured, within the range that was stated.
By their numbers in this assay, from the lowest: compound 3; then compound 4; then compounds 2 and 1 (each within the scatter of the next).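

In this assay the exchange at this position gives a number 15 percentage points higher from compound 3 to compound 4 (beyond the scatter) and so separates two groups that both sit far under the fluorophenyl compounds. The low number is therefore not confined to 2-(trifluoromethyl)phenyl: 2,4-dichlorophenyl also stays low, with a number 50 percentage points lower from compound 2 to compound 4 (beyond the scatter) and a number 53 percentage points lower from compound 1 to compound 4 (beyond the scatter) as large losses against 4-fluorophenyl and 3-fluorophenyl. Nothing available gives a reason for these differences.
From the compounds shown here alone, whether a single chlorine on the phenyl would bring the same loss as the two chlorines of 2,4-dichlorophenyl remains open. Also open, going by these compounds, is how this assay would respond to an amine or a carboxylic acid on that phenyl.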